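Compound 4: Swapping Dimethoxyphenyl for Fluorophenyl

The compounds below may be only part of what the source reports. "The series", "measured", "known", "first", "only" and "open" are said of these compounds alone.

Measured values in a functional assay on the whole organism (strain Kunming) with Mus musculus as the target, with a stated time of 0.5 h (a lower number here means that less compound is needed, a higher number that more compound is needed for the effect), are these

- compound 1 `COc1cc(OC)c(OC)cc1/C=C/COC(=O)/C=C/c1ccc(OC)c(OC)c1` gives 140 umol/kg
- compound 2 `COc1cc(OC)c(OC)cc1/C=C/COC(=O)/C=C/c1cc(OC)c(OC)c(OC)c1` gives 74.7 umol/kg
- compound 3 `COc1cc(OC)c(OC)cc1/C=C/COC(=O)/C=C/c1ccc(OC)c(OC)c1OC` gives 75.1 umol/kg

Compound 1 gives 140 umol/kg and cannot be clearly separated from the other two compounds. The measured steps are a 1.9-fold lower number from compound 1 to compound 2 (0.27 log units; within the scatter) and a 1.9-fold lower number from compound 1 to compound 3 (0.27 log units; within the scatter), so all three values sit close together.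

Compound 4 `COc1cc(OC)c(OC)cc1/C=C/COC(=O)/C=C/c1ccc(F)cc1` has not yet been measured. Its change from compound 1 is 4-fluorophenyl in place of 3,4-dimethoxyphenyl on a double-bonded chain carbon bound to a double-bonded chain carbon and the rest of the molecule stays the same.

Only those two measured steps bear on this change, and each is methoxy in place of hydrogen on an aromatic carbon. Within the data shown here, they are an imperfect guide, since compound 4 loses its methoxy groups and gains a fluorine, and no measured compound shows that swap. An added methoxy gave only a 1.9-fold lower number from compound 1 to compound 2 (0.27 log units; within the scatter) and so no step beyond the scatter is expected in this assay for its removal. At most, a slight lean towards a higher number is expected, the reverse of the direction of those steps. The expected step is a 1.2-fold higher number from compound 1 to compound 4 (0.08 log units; within the scatter) and it carries wide uncertainty. Compound 4 is estimated at 170 umol/kg with an expected range from 60 umol/kg to 450 umol/kg as its limits.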

Compound 4, dose for half-maximal effect: 92.9 umol/kg
Compound 4: the middle estimate sits 1.8-fold (0.26 log units) above what was measured; low and high end bracket the measured number.
By their numbers in this assay, from the lowest: compounds 2, 3, 4 and 1 (each within the scatter of the next).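

In this assay the whole 3,4-dimethoxyphenyl group on this double-bonded chain carbon gives way to 4-fluorophenyl with only a 1.5-fold lower number from compound 1 to compound 4 (0.18 log units; within the scatter) and no step beyond the scatter. The earlier compounds shown here only added a methoxy to a ring that already carried two, whereas this change removes every methoxy from that ring, going from 10 heavy atoms to 7 and from 2 hydrogen-bond acceptors to 0. Between compound 1 and compound 4, then, the methoxy groups on this ring are not required for the effect to stay at this level, and nothing available explains why the number holds.

As far as these compounds go, it remains open whether the fluorine matters at all, which a plain phenyl ring with no substituent would show, and whether a ring carrying an amine or a carboxylic acid would stay this close to compound 1. Every step shown lies within the scatter, so it is still unknown which change at this position, if any, would clearly move the number.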